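Compound 2 to compound 4: saturating a chain alkene

This account rests on a few compounds, and the source may have more. Where it says the series, first, only, none or still open, it means among the compounds named here.

Three amides have been read in a functional assay on NCI-H460 cells (Homo sapiens) for antiproliferative activity, read by sulforhodamine B assay, with a stated time of 48 h; on this read-out lower numbers stand for stronger inhibition of growth and higher numbers for weaker inhibition of growth. Compound 1 (`CCCCCCCC/C=C\CCCCCCCC(=O)N1CCCC1`) gives 45.6 ug/mL, compound 2 (`CCCCC/C=C\C/C=C\CCCCCCCC(=O)N1CCCCC1`) gives 29.1 ug/mL and compound 3 (`CCCCCCCCCCCCCCCC(=O)N1CCOCC1`) gives 34.1 ug/mL. At 29.1 ug/mL, compound 2 lies within the scatter of both other compounds, so the three values do not separate. Compound 4 (`CCCCCCCC/C=C\CCCCCCCC(=O)N1CCCCC1`) differs from compound 2 by heptyl in place of hept-1-en-1-yl on a saturated chain carbon bound to a double-bonded chain carbon, on a saturated chain carbon bound to a double-bonded chain carbon. Among the measured compounds shown here, no measured pair isolates this change. Compound 3 also carries a saturated chain and gives 34.1 ug/mL, so no shift beyond the scatter is expected. The expected step of a 1.2-fold higher number from compound 2 to compound 4 (0.07 log units; within the scatter) has no reliable direction. For compound 4 the estimated value is 34 ug/mL, with an expected range of 19 ug/mL to 60 ug/mL.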

Compound 4, concentration for 50% growth inhibition: 23 ug/mL
Beside the measured number, compound 4's estimate is 1.5-fold (0.17 log units) above it; the range from low to high includes it.
By their numbers in this assay, from the lowest: compounds 4, 2, 3 and 1 (each within the scatter of the next).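

In this assay, heptyl in place of hept-1-en-1-yl on a saturated chain carbon bound to a double-bonded chain carbon gives a 1.3-fold lower number from compound 2 to compound 4 (0.10 log units; within the scatter), so the first pair isolating this change does not resolve an effect of this double bond. Piperidin-1-yl in place of pyrrolidin-1-yl on a carbonyl carbon gives a 2.0-fold lower number from compound 1 to compound 4 (0.30 log units; within the scatter), which also stays within the scatter. Nothing available bears on either step. Still open, from the compounds shown here alone, is whether a longer chain, or a carboxylic acid in place of piperidin-1-yl, would separate from these values.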